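Working notes: 4-methylpiperazin-1-yl in place of dimethylamino

This account rests on a few compounds, and the source may have more. Where it says the series, first, only, none or still open, it means among the compounds named here.

Results so far in a functional assay on MCF7 cells (Homo sapiens) for antiproliferative activity, read by MTT assay, with a stated time of 72 h (a higher number here means a weaker inhibitor, a lower number a stronger inhibitor), are as follows
compound 1 `CN(C)CCn1cccc1/C=N/NC(=O)Nc1ccc(Oc2ccnc3[nH]ccc23)cc1` gives "not determined" (no result reported)
compound 2 `CN1CCN(CCCn2cccc2/C=N/NC(=O)Nc2ccc(Oc3ccnc4[nH]ccc34)c(F)c2)CC1` gives 3740 nM
compound 3 `CN(C)CCCn1cccc1/C=N/NC(=O)Nc1ccc(Oc2ccnc3[nH]ccc23)cc1` gives 9140 nM

Of the two numbers in hand, compound 3 at 9140 nM is the higher, and compound 2 at 3740 nM lies lower by more than the usual scatter. Compound 1 provides no number.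

Compound 4 `CN1CCN(CCCn2cccc2/C=N/NC(=O)Nc2ccc(Oc3ccnc4[nH]ccc34)cc2)CC1` comes from compound 3 through 4-methylpiperazin-1-yl in place of dimethylamino on a saturated chain carbon, three bonds along the chain from an aromatic nitrogen in one place. That place is a saturated chain carbon, three bonds along the chain from an aromatic nitrogen. Going by the values given here, no measured pair shows this change on its own, so the expectation rests on thin ground. Among the compounds with values here, compound 2 also carries the 4-methylpiperazin-1-yl group and gives 3740 nM in this assay as the only guide. A modest move to a lower number is therefore expected, close to the edge of the scatter, and the estimated 1.8-fold lower number from compound 3 to compound 4 (0.26 log units; within the scatter) is no more than a tentative figure. For compound 4 the estimated value is 5000 nM with an expected range from 2000 nM to 12000 nM in this series.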

Compound 4, half-maximal inhibitory concentration: 4280 nM
Estimate against measurement, compound 4: 1.2-fold (0.07 log units) above, and the stated range covers the measured number.
By their numbers in this assay, from the lowest: compounds 2 and 4 (each within the scatter of the next); then compound 3.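

In this assay, 4-methylpiperazin-1-yl in place of dimethylamino on a saturated chain carbon, three bonds along the chain from an aromatic nitrogen, can now be read on its own, and it gives a 2.1-fold lower number from compound 3 to compound 4 (0.33 log units; beyond the scatter). This is a modest step, so the lower number of compound 2 need not depend on its fluoro group. Hydrogen in place of fluoro on an aromatic carbon gives a 1.1-fold higher number from compound 2 to compound 4 (0.06 log units; within the scatter), and no data shown here give a cause for either step.

The compounds shown leave open whether a morpholine, a piperidine or a primary amine at this chain end would give a number different from that of compound 4. Also open, on these data alone, is how a longer chain would compare with the 3-(4-methylpiperazin-1-yl)propyl group.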